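Methylsulfanyl for Fluoro on the Anilide of Compound 1

The source may report more compounds than this note shows. Statements on the series, on what has been measured and on what is new or still open speak of the compounds shown alone.

Measured compounds:
compound 1 `O=C(CN1CCC(c2cccc[n+]2[O-])CC1)Nc1cccc(F)c1` — 160 nM
compound 2 `Oc1ccc(N2CCN(Cc3nc4ccccc4[nH]3)CC2)nc1` — 2.4 nM
compound 3 `Cc1cccc(NC(=O)CN2CCC(c3ccc(O)cn3)CC2)c1` — 3.8 nM

In a functional assay on HEK293 cells for agonist activity at D(4) dopamine receptor (Homo sapiens), read by FLIPR (a higher number here means that more compound is needed for the effect, a lower number that less compound is needed), compound 1 gives 160 nM, the highest of the three numbers measured. The nearest measured compound is compound 3, whose value of 3.8 nM lies well beyond the scatter from that of compound 1, and compound 2, at 2.4 nM, lies further still. Compound 3 shares the piperidinyl acetamide arrangement with compound 1 but differs from it in more than one place, so its lower number cannot be tied to any single change.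

Among the measured compounds shown here, compound 4 `CSc1cccc(NC(=O)CN2CCC(c3cccc[n+]3[O-])CC2)c1` is the one new compound. It differs from compound 1 in a single place: methylsulfanyl in place of fluoro on an aromatic carbon. For the measured compounds named here, no measured pair shows this exact change, so the size of the step in this assay is open. The account expects the change to give a small downward step or none beyond the scatter, with a wide range allowed. The step from compound 1 to compound 4 is estimated as a 1.8-fold lower number from compound 1 to compound 4 (0.25 log units; within the scatter). Compound 4 is therefore expected to give about 90 nM in this assay, with a likely range from 20 nM to 400 nM.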

Compound 4, half-maximal effective concentration: 100 nM
The estimate for compound 4 lay 1.1-fold (0.05 log units) below the measured number; the range from low to high includes it.
By their numbers in this assay, from the lowest: compounds 2 and 3 (each within the scatter of the next); then compounds 4 and 1 (each within the scatter of the next).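

Among the compounds shown here, compound 1 and compound 4 form the first pair here that differs in one place only, so the change from 3-fluorophenyl to 3-(methylsulfanyl)phenyl can now be read on its own in this assay, where it gives a 1.6-fold lower number from compound 1 to compound 4 (0.20 log units; within the scatter), a step within the scatter. For the compounds shown here, at this place on the aromatic ring, methylsulfanyl, which has more heavy atoms than fluoro and a hydrogen-bond acceptor that fluoro lacks, gives a number that cannot be told apart from that of fluoro, something the earlier compounds, which differ from one another in more than one place, could not show. Nothing at hand speaks to what lies behind this result.

From the compounds shown here alone, whether this place accepts any group as readily remains open, since an amine, a carboxylic acid or a longer chain such as ethylsulfanyl might give a quite different number. Going by these compounds, it is also open whether methylsulfanyl in place of fluoro gives a step of the same size at another place on the ring or on a different core.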